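Reversed amide at the pyrazole carbon bearing the carbamoyl

The source may report more compounds than this note shows. Statements on the series, on what has been measured and on what is new or still open speak of the compounds shown alone.

Measured so far in an assay on CHO-K1 cells for displacement of a labelled ligand from prostaglandin E2 receptor EP1 subtype (Homo sapiens); a lower number here means a stronger inhibitor, a higher number a weaker inhibitor:
compound 1 `Cc1cc(C(N)=O)nn1Cc1cc(Cl)ccc1OCc1ccccc1`, 126 nM
compound 2 `Cc1cc(C(=O)Nc2ccccn2)nn1Cc1cc(Cl)ccc1OCc1ccccc1`, 126 nM
compound 3 `Cc1cc(NC(=O)CC2CCCCC2)nn1Cc1cc(Cl)ccc1OCc1ccccc1`, 6.31 nM

Compound 1 stands level with compound 2 at the digits shown, the two together the highest numbers of the three; compound 3 sits a long way below both. The step of no change at the digits printed from compound 1 to compound 2 (within the scatter) shows that a pyridin-2-yl on the amide-type nitrogen leaves the number where it was. The step of a 20-fold lower number from compound 1 to compound 3 (1.30 log units; beyond the scatter), and likewise a 20-fold lower number from compound 2 to compound 3 (1.30 log units; beyond the scatter), show that turning the carbamoyl around into an acylamino group brings a large gain.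

Compound 4 `Cc1cc(NC(=O)c2ccccc2)nn1Cc1cc(Cl)ccc1OCc1ccccc1` carries the same shared core as compound 1 and differs only here: benzamido in place of carbamoyl on an aromatic carbon. This is the same turn of the amide as in compound 3, with a phenyl where compound 3 has a cyclohexylmethyl. On the strength of a 20-fold lower number from compound 1 to compound 3 (1.30 log units; beyond the scatter) a large drop in the number is expected for compound 4, though without a measured pair of phenyl against cyclohexylmethyl the size is uncertain. The expected step is a 7.9-fold lower number from compound 1 to compound 4 (0.90 log units; beyond the scatter), giving an estimate for compound 4 of 16 nM, between 5 nM and 50 nM.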

Compound 4, half-maximal inhibitory concentration: 15.9 nM
Estimate against measurement, compound 4: 1.0-fold (0.00 log units) above; the range from low to high includes it.
By their numbers in this assay, from the lowest: compound 3; then compound 4; then compounds 1 and 2 (each within the scatter of the next).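

In this assay, the reversed amide also gives a gain with an aromatic ring on its carbonyl: a 7.9-fold lower number from compound 1 to compound 4 (0.90 log units; beyond the scatter), and a 7.9-fold lower number from compound 2 to compound 4 (0.90 log units; beyond the scatter). The gain at this aromatic carbon is therefore not confined to the cyclohexylmethyl of compound 3, while the group on the carbonyl still affects the number, with a 2.5-fold higher number from compound 3 to compound 4 (0.40 log units; beyond the scatter) for phenyl in place of cyclohexylmethyl. Nothing measured here gives a reason for these steps.

Still open, on these data alone, is how much of the gain comes from the reversed amide itself and how much from the added carbon groups, a question that an acetamido group at this carbon would address. Also open, as far as these compounds go, is whether a pyridine ring on the carbonyl, or a longer chain between the carbonyl and the phenyl, would keep the lower number.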